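Swapping amino for azido on the shared core

The source may hold more compounds than are shown below. What is called first, only, known or untested is meant among the compounds shown, and "the series" means these compounds.

Values measured in an ADME assay on MDCK cells (Canis lupus familiaris) for cytotoxicity, read by MTT assay, with a stated time of 2 days; on this read-out higher numbers stand for lower toxicity in this test and lower numbers for higher toxicity in this test

Compound 1 `NCCCCc1ccc(-c2ccc(-c3cccs3)s2)s1` gives 13300 nM
Compound 2 `[N-]=[N+]=NCCCc1ccc(-c2ccc(-c3ccc(-c4cccs4)s3)s2)s1` gives > 100000 nM (a limit of the assay, not a number)
Compound 3 `NCCCc1ccc(-c2ccc(-c3cccs3)s2)s1` gives 18900 nM

Compound 3 gives 18900 nM, and it cannot be told apart from its nearest neighbour on the numbers: a 1.4-fold higher number from compound 1 to compound 3 (0.15 log units; within the scatter). Compound 4 `[N-]=[N+]=NCCCc1ccc(-c2ccc(-c3cccs3)s2)s1` keeps the core of compound 3 but has azido in place of amino on a saturated chain carbon, three bonds along the chain from an aromatic carbon. Among the compounds with values here, the one measured step involves no azido, so it offers little guidance on this change. Compound 2 does carry azido, and its > 100000 nM is a limit of the assay. Its core differs from that of compound 4, so it is only a hint, but it points to a higher number in this assay, meaning lower toxicity in this test. The expected change, beyond the scatter, is a 3.7-fold higher number from compound 3 to compound 4 (0.57 log units; beyond the scatter). For compound 4 the estimate is 70000 nM, with an expected range from 25000 nM to 100000 nM.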

Compound 4, half-maximal cytotoxic concentration: > 200000 nM
Compound 4: no number, only a limit (the forecaster's own chance of this, stated with the estimate: 45%); middle value at least 2.8-fold (0.45 log units) from the limit.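

Within the data shown here, this is the first direct comparison of azido and amino on one core. In this assay, azido in place of amino on this saturated chain carbon gives an at least 10-fold higher number from compound 3 to compound 4 (1.02 log units; beyond the scatter), meaning lower toxicity in this test, and the comparison with the aminomethyl compound runs the same way, with an at least 15-fold higher number from compound 1 to compound 4 (1.17 log units; beyond the scatter). Compound 4 has no exact number, so these steps rest on a limit of the assay: the limit of > 200000 nM in this assay, at which 1 of the 4 values shown sits.

From the compounds shown here alone, the step between compound 2 and compound 4 joins two limits and cannot be read, so the effect of the extra thiophen-2-yl on the azido compounds stays unknown. Also open, going by these compounds, is how a carboxylic acid or a hydroxyl at this chain position would compare, and whether a longer chain carrying azido would behave like compound 4.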